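Swapping a phenoxy for a halogenated benzyl on the core

The source may report more compounds than this note shows. Statements on the series, on what has been measured and on what is new or still open speak of the compounds shown alone.

Measured compounds:
compound 1, `c1ccc(Oc2ccc3c(NCCCNCc4ccco4)ccnc3c2)cc1`, 317 10^-6 cm/s
compound 2, `COc1ccc(F)cc1CNCCCNc1ccnc2cc(C3CCCCC3)ccc12`, 23 10^-6 cm/s
compound 3, `COc1ccc(F)cc1CNCCCNc1ccnc2cc(CCC(C)C)ccc12`, 23 10^-6 cm/s

In an ADME assay for permeability, using PAMPA, with a stated time of 30 min, at pH 7.4 (a higher number here means that the compound crosses the layer faster, a lower number that the compound crosses the layer more slowly), compound 1 gives 317 10^-6 cm/s, the highest of the three numbers, while compound 2 gives 23 10^-6 cm/s and compound 3 gives 23 10^-6 cm/s, both well beyond the scatter below compound 1. The step from compound 1 to compound 4 (`Fc1ccc(Cc2ccc3c(NCCCNCc4ccco4)ccnc3c2)c(Cl)c1`) is 2-chloro-4-fluorobenzyl in place of phenoxy on an aromatic carbon. Within the data shown here, the only measured step, no change at the digits printed from compound 2 to compound 3 (within the scatter), also alters a group on the shared core and left the reading untouched, but it concerns different groups and a compound already far lower. Among the measured compounds shown here, no measured step therefore speaks directly to this change; the expectation is a 1.1-fold lower number from compound 1 to compound 4 (0.05 log units; within the scatter). Compound 4 is estimated at 280 10^-6 cm/s, between 140 10^-6 cm/s and 560 10^-6 cm/s.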

Compound 4, apparent permeability: 23 10^-6 cm/s
Beside the measured number, compound 4's estimate is 12-fold (1.09 log units) above it, and the stated range ends above it.
By their numbers in this assay, from the lowest: compounds 2, 3 and 4 (each within the scatter of the next); then compound 1.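

In this assay the exchange of phenoxy for 2-chloro-4-fluorobenzyl on this aromatic carbon brings a 14-fold lower number from compound 1 to compound 4 (1.14 log units; beyond the scatter) and so shows that the reading depends strongly on the group held at this position. The earlier exchange of cyclohexyl for isopentyl had brought no change at the digits printed from compound 2 to compound 3 (within the scatter) and gave no sign that a single change on an aromatic carbon could move the reading this far. Nothing available here explains the size of this step.

As far as these compounds go, it remains open whether the benzyl link or the chlorine and fluorine carry the step. From the compounds shown here alone, how an unsubstituted benzyl or an anilino group would read at this position is also open.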